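This account rests on a few compounds, and the source may have more. Where it says the series, first, only, none or still open, it means among the compounds named here.

Compound 1 `N#C/C(=C\c1ccc[nH]1)C(=O)NCc1ccc(Cl)c(Cl)c1` is one of the two compounds measured in a functional assay on A-431 cells (Homo sapiens) for inhibition, read by MTT assay, with a stated time of 72 h; on this read-out higher numbers stand for weaker inhibition of growth and lower numbers for stronger inhibition of growth. In this assay compound 1 gives no number but only a limit, > 50000 nM. The other compound, compound 2 `COc1ccc(CNC(=O)/C(C#N)=C/c2ccoc2)cc1`, gives 5000 nM in this assay. Compound 1 therefore stands at the end of the numbers shown where inhibition of growth is weakest, a position marked by the limit of > 50000 nM in this assay, at which 1 of the 2 values shown sits, and as a limit it sets no exact gap to compound 2.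

Compound 3 `N#C/C(=C\c1ccccc1)C(=O)NCc1ccc(Cl)c(Cl)c1` differs from compound 1 in a single place: phenyl in place of 1H-pyrrol-2-yl on a double-bonded chain carbon bound to a double-bonded chain carbon. Among the compounds with values here, no measured pair of compounds shows this particular exchange, so the size of the step is open and rests on what the two measured values allow. The expected step is an at least 2.5-fold lower number from compound 1 to compound 3 (0.39 log units; beyond the scatter), a moderate move toward stronger inhibition of growth, with a real chance that this assay again reports only a limit. Compound 3 is estimated at 20000 nM in this assay, with a range from 3000 nM to 80000 nM.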

Compound 3, concentration for 50% growth inhibition: 43000 nM
Estimate against measurement, compound 3: 2.2-fold (0.33 log units) below, within the range that was stated.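

The exchange of 1H-pyrrol-2-yl for phenyl at this position brings the series a measured number with the amide side of compound 1 left unchanged: in this assay compound 3 gives 43000 nM. Compound 1 has only a limit in this assay, > 50000 nM, so the change can be read only as an at least 1.1-fold lower number from compound 1 to compound 3 (0.06 log units; that floor lies within the scatter). This exchange also removes the hydrogen-bond donor counted on the 1H-pyrrol-2-yl group, yet the data do not show that the phenyl compound truly differs from compound 1, and the true size of the step stays unknown because one end of it is not a number: the limit of > 50000 nM in this assay, at which 1 of the 3 values shown sits.

Within the data shown here, compound 2 differs from compound 1 and compound 3 in more than one place, so it cannot show what the group at this position contributes on its own, and no step to it can be read. What the compounds shown leave open is how a phenyl carrying a hydroxyl group, or a pyridine ring, would behave on this same double-bonded chain carbon, and whether any such group would move the value clearly beyond the scatter.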